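A few compounds are considered here, and "the series" means these few. Any claim that something is new, unique, unknown or untested is made for them only; others in the source may bear on it.

Measured compounds:
compound 1 `COC(=O)c1ccc(C)cc1OC(=O)COc1cc(O)c2c(=O)cc(-c3ccccc3)oc2c1`: 250000 nM
compound 2 `COC(=O)c1cc(F)ccc1OC(=O)COc1cc(O)c2c(=O)cc(-c3ccccc3)oc2c1`: 389000 nM

In an ADME assay on cells (T-cell, Mus musculus, strain BALB/c) for cytotoxicity, read by MTT assay, with a stated time of 48 h (on this read-out lower numbers stand for higher toxicity in this test and higher numbers for lower toxicity in this test), compound 1 gives 250000 nM and compound 2 gives 389000 nM; compound 2 holds the highest of the two numbers, with compound 1 nearest, a gap that is a 1.6-fold higher number from compound 1 to compound 2 (0.19 log units; within the scatter). Compound 3 `COC(=O)c1ccc(Br)cc1OC(=O)COc1cc(O)c2c(=O)cc(-c3ccccc3)oc2c1` is not yet measured. It differs from compound 2 in the following way: a group of 11 heavy atoms (8 carbon, 2 oxygen, 1 bromine; one six-membered aromatic ring of carbon only) in place of a group of 11 heavy atoms (8 carbon, 2 oxygen, 1 fluorine; one six-membered aromatic ring of carbon only), on an oxygen next to a carbonyl group. Among the measured compounds shown here, the only measured step that bears on this change is the one at the same place, from compound 1 to compound 2, which was a 1.6-fold higher number from compound 1 to compound 2 (0.19 log units; within the scatter), so a swap of one group for another on this oxygen has so far left the number where it was. On that basis the step to compound 3 is expected to stay within the scatter, as a 1.2-fold lower number from compound 2 to compound 3 (0.08 log units; within the scatter). Compound 3 is therefore estimated at 320000 nM, with a range from 150000 nM to 650000 nM.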

Compound 3, half-maximal cytotoxic concentration: 326000 nM
Estimate against measurement, compound 3: 1.0-fold (0.01 log units) below, within the range that was stated.
By their numbers in this assay, from the lowest: compounds 1, 3 and 2 (each within the scatter of the next).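

In this assay, replacing the fluorine-bearing group with the bromine-bearing group on an oxygen next to a carbonyl group gives a 1.2-fold lower number from compound 2 to compound 3 (0.08 log units; within the scatter), so a third group at this place also leaves the number within the scatter. The new compound also gives a cleaner comparison, bromo in place of methyl on an aromatic carbon, and this change gives a 1.3-fold higher number from compound 1 to compound 3 (0.12 log units; within the scatter), which means that the three compounds cannot be ordered in this test. Nothing in the data shown offers an explanation for these small steps.

Going by these compounds, the three compounds vary only in a methyl, fluoro or bromo group on this aromatic ring, so it remains open whether an amine or a carboxylic acid there would give a step beyond the scatter. The same question stands for a longer chain on the ester.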